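A few compounds are considered here, and "the series" means these few. Any claim that something is new, unique, unknown or untested is made for them only; others in the source may bear on it.

Compound 1 `CN(C)c1ccc(NCc2cncn2Cc2ccc(-c3ccccc3)cc2)cc1-c1ccccc1`: > 1000 nM
Compound 2 `COC(=O)c1ccc(NCc2cncn2Cc2ccccc2C)cc1-c1ccccc1`: 10000 nM
Compound 3 `COC(=O)c1ccc(NCc2cncn2Cc2cccc(F)c2)cc1-c1ccccc1`: > 1000 nM

Of the compounds shown here, three have been measured in a toxicity assay on NIH3T3 cells (Mus musculus) for cytotoxicity, read by resazurin assay; a lower number here means that less compound is needed, a higher number that more compound is needed for the effect. For compound 1 the result > 1000 nM is a limit of the assay, not a number. Among the compounds with values here, compound 2 gives 10000 nM in this assay, the only numerical value among the three. For compound 3 the result > 1000 nM is again a limit. Within the data shown here, the single one-place step between measured compounds, a step that the limit leaves unreadable from compound 2 to compound 3, is 3-fluorophenyl in place of 2-methylphenyl on a saturated chain carbon bound to an aromatic nitrogen, and its size cannot be read. From the compounds shown here alone, compound 1 thus stands at the limit of > 1000 nM in this assay, at which 2 of the 3 values shown sit, and where exactly it lies beyond that is unknown.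

Compound 4 `c1ccc(-c2ccc(Cn3cncc3CNc3ccc(N4CCCCC4)c(-c4ccccc4)c3)cc2)cc1` has not yet been measured. It differs from compound 1 by piperidin-1-yl in place of dimethylamino on an aromatic carbon. Among the measured compounds shown here, no measured step touches that position, so none of the measured steps bears on it directly, and the measured compounds give no readable trend at all. Compound 4 is therefore expected to give 5000 nM in this assay, with a range from 1500 nM to 20000 nM. The step that the limit leaves unreadable from compound 1 to compound 4 that this estimate means is expected to stay within the scatter, and the result may again be reported only as a limit.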

Compound 4, half-maximal effective concentration: > 1000 nM
Compound 4: a limit, no number (the forecaster's own chance of this, stated with the estimate: 50%); the middle value does not contradict the limit.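

In this assay compound 4 gives > 1000 nM, a limit and not a number, and compound 1 also gives only a limit, so no new step can be read between them. The compounds shown leave open whether piperidin-1-yl in place of dimethylamino changes the result at all, and where compound 1 and compound 4 actually lie: the limit of > 1000 nM in this assay, at which 3 of the 4 values shown sit.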